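This account rests on a few compounds, and the source may have more. Where it says the series, first, only, none or still open, it means among the compounds named here.

Measured so far:
compound 1, `COc1ccc(C(=O)Nc2ncc(-c3ccc(OC)cc3)n2C)cc1`, in a toxicity assay on THP-1 cells (Homo sapiens) for inhibition (on this read-out lower numbers stand for higher toxicity in this test and higher numbers for lower toxicity in this test), a limit of > 100000 nM;
compound 2, `COc1ccc(-c2cnc(NC(=O)c3ccc(Br)cc3)n2C)cc1`, in this assay a limit of > 100000 nM;
compound 3, `COc1ccc(-c2cnc(NC(=O)c3ccccc3C#N)n2C)cc1`, in this assay a limit of > 100000 nM.

Compound 3 thus stands at the same limit as the two others, as the limit of > 100000 nM in this assay, at which 3 of the 3 values shown sit, records. Compound 4, `COc1ccc(-c2cnc(NC(=O)c3ncc[nH]3)n2C)cc1`, differs from it by 1H-imidazol-2-yl in place of 2-cyanophenyl on a carbonyl carbon. The earlier steps shown here a step that the two limits leave unreadable from compound 1 to compound 2, a step that the two limits leave unreadable from compound 1 to compound 3 and a step that the two limits leave unreadable from compound 2 to compound 3 all exchange groups on the carbonyl carbon or on an aromatic carbon, yet none has a readable size, so nothing supports a step beyond the scatter in this assay in either direction. Compound 4 is therefore estimated at 100000 nM, with a range from 30000 nM to 300000 nM. The step of a number no higher from compound 3 to compound 4 (the limit leaves the size open) is expected to be none beyond the scatter, most likely again a limit.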

Compound 4, half-maximal cytotoxic concentration: > 100000 nM
Compound 4 ended at the assay's limit; the forecaster's own chance of this, stated with the estimate: 80%; the middle value lies on the limit itself.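

Compound 4 is a limit, as are compound 1, compound 2 and compound 3, so no step among them can be read in this assay: the limit of > 100000 nM in this assay, at which 4 of the 4 values shown sit.

The compounds shown leave open whether any exchange on the carbonyl carbon gives a readable value in this assay.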